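Benzyl Ring Substituents in a Thiourea Series

This account rests on a few compounds, and the source may have more. Where it says the series, first, only, none or still open, it means among the compounds named here.

Measured compounds:
compound 1 `Cc1ccc(NC(=S)NC(=O)c2ccc(OCc3ccccc3)cc2)cc1-c1nc2ccccc2[nH]1` gives 57800 nM
compound 2 `Cc1ccc(NC(=S)NC(=O)c2ccc(OCc3cccc(C(F)(F)F)c3)cc2)cc1-c1nc2ccccc2[nH]1` gives 6050 nM
compound 3 `Cc1ccc(NC(=S)NC(=O)c2ccc(OCc3ccc(Cl)cc3Cl)cc2)cc1-c1nc2ccccc2[nH]1` gives 5300 nM

In a functional assay on MNK45 cells (Homo sapiens) for inhibition, read by MTT assay, with a stated time of 48 h (on this read-out lower numbers stand for stronger inhibition and higher numbers for weaker inhibition), compound 3 holds the lowest number of the three, but its nearest neighbour sits within the scatter, as a 1.1-fold lower number from compound 2 to compound 3 (0.06 log units; within the scatter) shows, so compounds 2 and 3 cannot be placed in an order. Only compound 1 stands clearly apart: an 11-fold lower number from compound 1 to compound 3 (1.04 log units; beyond the scatter) is a large step, and a 9.6-fold lower number from compound 1 to compound 2 (0.98 log units; beyond the scatter) a modest one.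

Compound 4 `Cc1ccc(NC(=S)NC(=O)c2ccc(OCc3ccc(F)cc3)cc2)cc1-c1nc2ccccc2[nH]1` differs from compound 3 in one place: 4-fluorophenyl in place of 2,4-dichlorophenyl on a saturated chain carbon bound to an oxygen on an aromatic ring. Going by the values given here, two measured steps bear on this. The step from the plain phenyl of compound 1 to the 2,4-dichlorophenyl of compound 3 lowered the number strongly, and a single trifluoromethyl on that ring in compound 2 did nearly as much. Among the compounds with values here, compound 4 carries only one fluorine on the ring; nothing measured here shows what a single fluorine does in place of hydrogen, so the expectation is that the number moves back toward compound 1 without reaching it. Compound 4 is therefore expected to show a 4.7-fold higher number from compound 3 to compound 4 (0.67 log units; beyond the scatter) in this assay. The estimate for compound 4 is 25000 nM, within a range of 8000 nM to 70000 nM.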

Compound 4, half-maximal inhibitory concentration: 4220 nM
For compound 4 the middle estimate is 5.9-fold (0.77 log units) above the measured one; the whole stated range lies above it.
By their numbers in this assay, from the lowest: compounds 4, 3 and 2 (each within the scatter of the next); then compound 1.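

Compound 1, with its plain phenyl, now stands apart from a third ring as well: a 14-fold lower number from compound 1 to compound 4 (1.14 log units; beyond the scatter) in this assay, so a single fluoro in place of hydrogen on an aromatic carbon is enough for a step beyond the scatter, which the earlier compounds had shown only for trifluoromethyl and for the two chlorines of 2,4-dichlorophenyl. The three substituted rings cannot be told apart, with a 1.3-fold lower number from compound 3 to compound 4 (0.10 log units; within the scatter) and a 1.4-fold lower number from compound 2 to compound 4 (0.16 log units; within the scatter), so among these compounds neither the kind of substituent nor the count of them on this ring makes a readable difference in this assay. Nothing available here accounts for why these three rings fall so close together.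

The compounds shown leave open whether a methyl, a methoxy or an amine on this ring would give a step from compound 1 like that of fluoro, and whether a carboxylic acid there would do the same. Also open, going by these compounds, is whether a longer chain in place of the single saturated carbon bound to the oxygen would keep the numbers of compounds 2, 3 and 4.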